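This account rests on a few compounds, and the source may have more. Where it says the series, first, only, none or still open, it means among the compounds named here.

Measured in a functional assay on HL-60 cells (Homo sapiens) for cytotoxicity, read by WST assay, with a stated time of 48 h; a lower number here means that less compound is needed, a higher number that more compound is needed for the effect:
- Compound 1 `O=C1OC[C@H](Cc2ccccc2)[C@H]1Cc1ccccc1`: 77000 nM.
- Compound 2 `O=C1OC[C@H](Cc2ccccc2)[C@H]1Cc1cccc(O)c1`: > 100000 nM, a limit of the assay and not a number.
- Compound 3 `CCCCOc1cccc(C[C@H]2C(=O)OC[C@@H]2Cc2ccccc2)c1`: 26000 nM.

Compound 3 holds the lower of the two actual numbers in this assay. Its nearest neighbour is one step away: a 3.0-fold lower number from compound 1 to compound 3 (0.47 log units; beyond the scatter). The third value is a limit, and the step from it is an at least 3.8-fold lower number from compound 2 to compound 3 (0.58 log units; beyond the scatter).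

Next is compound 4 `CCCCOc1cc(C[C@H]2C(=O)OC[C@@H]2Cc2ccccc2)ccc1O`, which carries a hydroxy in place of hydrogen on an aromatic carbon, ortho to a butoxy group and para to a large group: hydroxy in place of hydrogen on an aromatic carbon.

Among the measured compounds shown here, the closest precedent is the same exchange in compound 2: an at least 1.2-fold higher number from compound 1 to compound 2 (0.11 log units; that floor lies within the scatter). That size is only a floor, and it gives a direction at best. In compound 2 the hydroxy has no butoxy group on its ring, so the precedent is imperfect. The butoxy group is the one change shown to lower the number, as in a 3.0-fold lower number from compound 1 to compound 3 (0.47 log units; beyond the scatter), and compound 4 keeps it.

A small move towards a higher number is therefore expected in this assay, quite possibly none beyond the scatter. The estimate corresponds to an expected 1.3-fold higher number from compound 3 to compound 4 (0.13 log units; within the scatter). The estimated value for compound 4 is 35000 nM, with an expected range from 12000 nM to 100000 nM.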

Compound 4, half-maximal effective concentration: 35000 nM
Beside the measured number, compound 4's estimate shows no gap at the digits printed; low and high end bracket the measured number.
By their numbers in this assay, from the lowest: compounds 3 and 4 (each within the scatter of the next); then compound 1. At a limit, above all of these: compound 2.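

Notes on the hydroxy at this place: on the butoxy-bearing ring, ortho to a butoxy group and para to a large group, the exchange of hydrogen for hydroxy now has a readable size in this assay, and the step stays within the scatter: a 1.3-fold higher number from compound 3 to compound 4 (0.13 log units; within the scatter). The earlier precedent could give only a floor, as compound 2 sits at a limit of the assay and not at a number: the limit of > 100000 nM in this assay, at which 1 of the 4 values shown sits. The same change can now be set side by side on two cores, and both readings are small, though no difference between them can be established: the same change on two cores in this assay, an at least 1.2-fold higher number (0.11 log units; that floor lies within the scatter) from compound 1 to compound 2 and a 1.3-fold higher number (0.13 log units; within the scatter) from compound 3 to compound 4; the limit leaves it open whether they differ.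

The compounds shown leave open whether an amine or a carboxylic acid at this place would leave the number within the scatter of compound 3, and whether a longer chain in place of the butoxy group would change it. They also do not separate the effect of the place on the ring from the effect of the butoxy group, as the two hydroxy compounds differ in both.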